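Swapping the amino group of compound 1 for butyl(methyl)amino

The source may hold more compounds than are shown below. What is called first, only, known or untested is meant among the compounds shown, and "the series" means these compounds.

Compound 1 (`Cc1ccc(-c2cc3nc(N)[nH]c(=O)c3s2)cc1`) offers no number to start from: in an ADME assay on HepG2 cells (Homo sapiens) for cytotoxicity, read by MTT assay, with a stated time of 72 h (on this read-out higher numbers stand for lower toxicity in this test and lower numbers for higher toxicity in this test), compound 1 is recorded as "nd(insoluble)" (no result reported) with no half-maximal cytotoxic concentration reported. Among the measured compounds shown here, the only measured neighbour is compound 2 (`CCCCNc1nc2cc(-c3ccc(C)cc3)sc2c(=O)[nH]1`), and compound 2 gives 6000 nM in this assay as the sole number available. Compound 3 (`CCCCN(C)c1nc2cc(-c3ccc(C)cc3)sc2c(=O)[nH]1`) carries butyl(methyl)amino in place of amino on an aromatic carbon, between two ring nitrogen atoms (butyl(methyl)amino in place of amino on an aromatic carbon). For the measured compounds named here, with no value for compound 1, no step from it can be sized. In this assay compound 3 is instead expected to land near compound 2 at 6000 nM with no step beyond the usual scatter in either direction. The estimated value for compound 3 is 7000 nM with an expected range from 2500 nM to 20000 nM as its bounds.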

Compound 3, half-maximal cytotoxic concentration: 3000 nM
Beside the measured number, compound 3's estimate is 2.3-fold (0.37 log units) above it, within the range that was stated.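

In this assay, methyl in place of hydrogen on a nitrogen on an aromatic ring gives a 2.0-fold lower number from compound 2 to compound 3 (0.30 log units; within the scatter), so at this place, on an aromatic carbon between two ring nitrogen atoms, the nitrogen of compound 2 takes the added methyl with no step beyond the scatter. Among the compounds shown here, compound 1 has no number, so no step from it can be read, and the full swap of amino for butyl(methyl)amino stays unsized. No evidence at hand bears on this result.

On these data alone, it remains open whether a longer chain on this nitrogen, such as hexyl, would stay within the scatter of compound 3. The same question stands for a cyclic amine such as morpholine or for a carboxylic acid at the end of the butyl chain.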